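Oxetane-bearing amide in a pyridine-alkyne modulator series

This account rests on a few compounds, and the source may have more. Where it says the series, first, only, none or still open, it means among the compounds named here.

Measured compounds in a functional assay on HEK293 cells for positive allosteric modulation of metabotropic glutamate receptor 5 (Rattus norvegicus), read by fluorescence and calcium flux; on this read-out lower numbers stand for smaller maximal responses and higher numbers for larger maximal responses:
compound 1 `C[C@@H](NC(=O)c1ccc(C#Cc2ccccc2)cn1)C(C)(C)O`: 60.9%
compound 2 `C[C@@H](NC(=O)c1cnc(C#Cc2cccc(F)c2)nc1)C(C)(C)O`: 68.7%
compound 3 `CC(C)[C@@H](C)NC(=O)c1ccc(C#Cc2cccc(F)c2)cn1`: 69.3%

Compound 3 carries the largest of the three numbers, but its gaps to compound 2 and to compound 1 both lie within the usual scatter of repeated measurements, so the three compounds cannot be told apart on this read-out; no ordering among them is supported.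

Compound 4 `CC1(CCNC(=O)c2ccc(C#Cc3cccc(F)c3)cn2)COC1` has not yet been measured in this assay. It differs from compound 3 in one place: 2-(3-methyloxetan-3-yl)ethyl in place of 1,2-dimethylpropyl on an amide-type nitrogen. The 1,2-dimethylpropyl group leaves and the 2-(3-methyloxetan-3-yl)ethyl group enters, on an amide-type nitrogen whose other neighbour is the carbonyl carbon. No step between measured compounds changes this position alone, so nothing shown here fixes the size of the step. The measured compounds span only a narrow band on the amide side, and a similar outcome is expected.

The expected step of a number 7.3 percentage points lower from compound 3 to compound 4 (within the scatter) is estimated to stay within the scatter, if anything slightly downward. Compound 4 is expected to give 62%, with a range from 45% to 80%.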

Compound 4, largest response reached (reported as efficacy), in percent of the reference or control that the assay uses: 65.7%
Beside the measured number, compound 4's estimate is 3.7 percentage points below it; the range from low to high includes it.
By their numbers in this assay, from the lowest: compounds 1, 4, 2 and 3 (each within the scatter of the next).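

In this assay, going by these compounds alone, 2-(3-methyloxetan-3-yl)ethyl in place of 1,2-dimethylpropyl on the amide-type nitrogen gives a number 3.6 percentage points lower from compound 3 to compound 4 (within the scatter), the first step that can be read at this position. The read-out therefore does not separate the two groups, even though the entering group brings a four-membered ring and a hydrogen-bond acceptor and the defined stereocentre of the leaving group is gone. Nothing measured here accounts for this outcome.

This single step cannot show whether the ring oxygen matters, and a 2-(1-methylcyclobutyl)ethyl group, with carbon in place of that oxygen, would address this directly. From the compounds shown here alone, how far this position tolerates other groups also remains open, for example a chain ending in an amine or a carboxylic acid.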